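A Butyl Ester in Place of the Aryl Side Chain

A few compounds are considered here, and "the series" means these few. Any claim that something is new, unique, unknown or untested is made for them only; others in the source may bear on it.

Compound 1 `C/C=C1/[C@H](O[C@@H]2O[C@H](CO)[C@@H](O)[C@H](O)[C@H]2O)OC=C(C(=O)OC)[C@H]1CC(=O)OCCCc1ccc(OC)c(OC)c1` was tested in a functional assay on SK-BR-3 cells (Homo sapiens) for antiproliferative activity, read by MTT assay, with a stated time of 72 h; a lower number here means a stronger inhibitor, a higher number a weaker inhibitor. In this assay compound 1 gives > 20000 nM, which is a limit of the assay and not a number, so compound 1 stands only at a limit among the values shown. Two relatives share its core. Compound 2 `C/C=C1/[C@H](O[C@@H]2O[C@H](COC(C)=O)[C@@H](OC(C)=O)[C@H](OC(C)=O)[C@H]2OC(C)=O)OC=C(C(=O)OC)[C@H]1CC(=O)O` gives > 15000 nM in this assay, again a limit and not a number. Compound 3 `C/C=C1/[C@H](O[C@@H]2O[C@H](COC(C)=O)[C@@H](OC(C)=O)[C@H](OC(C)=O)[C@H]2OC(C)=O)OC=C(C(=O)OC)[C@H]1CC(=O)OCCC` gives 6600 nM in this assay. Within the data shown here, the single measured step, an at least 2.2-fold lower number from compound 2 to compound 3 (0.35 log units; beyond the scatter), concerns a change unlike the one now considered. Compound 4 `C/C=C1/[C@H](O[C@@H]2O[C@H](CO)[C@@H](O)[C@H](O)[C@H]2O)OC=C(C(=O)OC)[C@H]1CC(=O)OCCCC` arises from compound 1 by methyl in place of 3,4-dimethoxyphenyl on a saturated chain carbon, three bonds along the chain from an oxygen next to a carbonyl group. Among the measured compounds shown here, no measured step covers this change, so no direction beyond the scatter is expected. Compound 4 is expected to give 15000 nM in this assay, between 5000 nM and 40000 nM, an expected step of an at least 1.3-fold lower number from compound 1 to compound 4 (0.12 log units; that floor lies within the scatter).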

Compound 4, half-maximal inhibitory concentration: > 15000 nM
Compound 4 ended at the assay's limit (the forecaster's own chance of this, stated with the estimate: 50%); the middle value sits exactly at the limit.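

Compound 1 and compound 4 both stand at limits of this assay, not at numbers, so the step between them cannot be read. Going by these compounds, whether methyl in place of 3,4-dimethoxyphenyl changes activity at all remains open.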